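The compounds below may be only part of what the source reports. "The series", "measured", "known", "first", "only" and "open" are said of these compounds alone.

Measured compounds:
compound 1, `C[C@H]1CC[C@@H]2[C@@H](OC(=O)[C@]23CC(c2cccc([N+](=O)[O-])c2)=NO3)[C@]2(C)C(=O)C=C[C@@]12O` — 1.37
compound 2, `COc1ccc(C2C[C@@]3(ON2c2ccccc2)C(=O)O[C@@H]2[C@H]3CC[C@H](C)[C@]3(O)C=CC(=O)[C@@]23C)cc1` — 3.25

In a physicochemical assay for lipophilicity (a higher number here means a more lipophilic compound, a lower number a more polar compound), compound 2 gives the higher of the two numbers; compound 1 sits well below it, beyond the scatter. Compound 3, `C[C@H]1CC[C@@H]2[C@@H](OC(=O)[C@]23CC(c2ccccc2F)N(c2ccccc2)O3)[C@]2(C)C(=O)C=C[C@@]12O`, has not yet been measured. It is reached from compound 2 by one change: 2-fluorophenyl in place of 4-methoxyphenyl on a saturated ring carbon. Going by the values given here, no measured pair shows this change, so no measured step guides it. The account expects a small step, not beyond the scatter, for a number 0.10 log units higher from compound 2 to compound 3 (within the scatter), with compound 3 estimated at 3.35, in a range from 2.9 to 3.8.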

Compound 3, partition coefficient: 3.35
Compound 3: middle estimate and measured number agree at the digits printed, and the stated range covers the measured number.
By their numbers in this assay, from the lowest: compound 1; then compounds 2 and 3 (each within the scatter of the next).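

In this assay, going by these compounds alone, the change to 2-fluorophenyl in place of 4-methoxyphenyl on this saturated ring carbon gives a number 0.10 log units higher from compound 2 to compound 3 (within the scatter) and is the first measured step at this position. The 4-methoxyphenyl group carries a hydrogen-bond acceptor and the 2-fluorophenyl group carries none, yet the two compounds stay within the scatter of each other. Nothing measured here accounts for this result. The compounds shown leave open whether an amine or a carboxylic acid on this ring carbon would give a step beyond the scatter.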